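A few compounds are considered here, and "the series" means these few. Any claim that something is new, unique, unknown or untested is made for them only; others in the source may bear on it.

Two compounds of the series carry a number in an assay on microsomes for inhibition of Amine oxidase [flavin-containing] A (Homo sapiens), read by fluorescence and spectrophotometry, with a stated time of 20 min; on this read-out higher numbers stand for weaker inhibition and lower numbers for stronger inhibition. Compound 1 `O=c1ccoc2ccc(OCCCc3ccccc3)cc12` gives 1910 nM in this assay. Compound 2 `O=c1ccoc2ccc(OCc3cccc(Cl)c3)cc12` gives 424 nM and so holds the lower of the two numbers; its gap to compound 1 lies beyond the scatter, which places compound 2 as the stronger inhibitor of the pair. Among the measured compounds shown here, no step between two measured compounds that differ in a single place is available, so the size of one isolated change has not yet been seen.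

Compound 3 `Cc1cccc(COc2ccc3occc(=O)c3c2)c1` has not been measured. It differs from compound 2 in one place: methyl in place of chloro on an aromatic carbon. The step of a 1.4-fold higher number from compound 2 to compound 3 (0.15 log units; within the scatter) is expected to be small, a modest weakening at most, and may well stay within the scatter. Compound 3 is therefore estimated at 600 nM in this assay, with a range from 250 nM to 1500 nM.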

Compound 3, half-maximal inhibitory concentration: 1130 nM
For compound 3 the middle estimate is 1.9-fold (0.27 log units) below the measured one; measured number inside the range.
By their numbers in this assay, from the lowest: compound 2; then compounds 3 and 1 (each within the scatter of the next).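

In this assay, among the compounds shown here, the exchange of chloro for methyl on an aromatic carbon, meta to a large group, gives a 2.7-fold higher number from compound 2 to compound 3 (0.43 log units; beyond the scatter), the first change in a single place that can be read. The two groups each count one heavy atom, and neither has a hydrogen-bond donor or acceptor or a net charge, yet the assay separates them, with chloro holding the lower number, so this position is not indifferent to its substituent, though the step is only modest in size. Nothing at hand bears on what lies behind this difference.

Open, as far as these compounds go, is how fluoro, bromo, methoxy or an amine would read at this same carbon. Also open, from the compounds shown here alone, is whether chloro and methyl would keep this order on another carbon of the ring or with a longer chain linking that ring to the shared core.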